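This account rests on a few compounds, and the source may have more. Where it says the series, first, only, none or still open, it means among the compounds named here.

Compound 2, `CCCC1CCCCC1OCCCCCCN1C[C@H](O)[C@@H](O)[C@H](O)[C@H]1CO`, is the hexyl-linked ether in which the ring on the oxygen carries a propyl group. In an ADME assay on MDBK cells (Bos taurus) for cytotoxicity, read by MTT assay (a lower number here means that less compound is tolerated, a higher number that more compound is tolerated), compound 2 gives 150000 nM, the lowest of the two numbers measured, with compound 1, `CC1CC(OCCCCCCN2C[C@H](O)[C@@H](O)[C@H](O)[C@H]2CO)CC(C)(C)C1`, nearest at 250000 nM; the step of a 1.7-fold lower number from compound 1 to compound 2 (0.22 log units; within the scatter) lies within the scatter. For compound 3, `CC1CCC(OCCCCCCN2C[C@H](O)[C@@H](O)[C@H](O)[C@H]2CO)CC1C`, this assay reports only a limit, > 500000 nM, and that limit is one of the values counted in the limit of > 500000 nM in this assay, at which 1 of the 3 values shown sits. The steps of an at least 2.0-fold higher number from compound 1 to compound 3 (0.30 log units; that floor lies within the scatter) and an at least 3.3-fold higher number from compound 2 to compound 3 (0.52 log units; beyond the scatter) show that swapping one ring group for another can move the number at the edge of the scatter or somewhat beyond it.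

Compound 4, `OC[C@@H]1[C@@H](O)[C@H](O)[C@@H](O)CN1CCCCCCOC1CCCCC1C1CCCCC1`, differs from compound 2 by cyclohexyl in place of propyl on a saturated ring carbon. Among the measured compounds shown here, no measured step exchanges a substituent on the ring in this way; the measured steps exchanged whole ring groups and ranged from within the scatter to modest. Compound 4 is therefore expected to shift by a 1.9-fold lower number from compound 2 to compound 4 (0.27 log units; within the scatter) in this assay, a modest move toward a lower number. The estimate for compound 4 is 80000 nM, within 30000 nM to 250000 nM.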

Compound 4, half-maximal cytotoxic concentration: 200000 nM
Beside the measured number, compound 4's estimate is 2.5-fold (0.40 log units) below it, within the range that was stated.
By their numbers in this assay, from the lowest: compounds 2, 4 and 1 (each within the scatter of the next). At a limit, above all of these: compound 3.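

In this assay, cyclohexyl in place of propyl on a saturated ring carbon, next to the ring atom that bears a large group, gives a 1.3-fold higher number from compound 2 to compound 4 (0.12 log units; within the scatter). This is the first step shown that exchanges only a substituent on the ring rather than a whole ring group, and it shows that at this position an open propyl chain and a cyclohexyl ring cannot be told apart in this assay. Nothing measured here bears on the reason for this result.

On these data alone, whether an amine or a carboxylic acid at this position, or a longer chain in place of propyl, would move the number beyond the scatter remains open. Also open, as far as these compounds go, is whether the same exchange would read differently with a linker other than the hexyl chain shared by compound 2 and compound 4.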